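Compound 1 to compound 3: replacing trifluoromethyl

The compounds below may be only part of what the source reports. "The series", "measured", "known", "first", "only" and "open" are said of these compounds alone.

Measured so far in an ADME assay on microsomes from liver (Rattus norvegicus) for metabolic stability, with a stated time of 10 min; on this read-out higher numbers stand for a more stable compound and lower numbers for a less stable compound:
- compound 1 `FC(F)(F)c1ccccc1-c1ccc2[nH]c(C3=NOC4(CCCCC4)C3)nc2c1` gives 75%
- compound 2 `FC(F)(F)c1ccccc1-c1cc(Cl)c2[nH]c(C3=NOC4(CCCCC4)C3)nc2c1` gives 100%

Not yet measured:
- compound 3 `CC(C)(O)c1ccccc1-c1ccc2[nH]c(C3=NOC4(CCCCC4)C3)nc2c1`

In this assay compound 1 holds the lower of the two numbers, at 75%. The next compound under review, compound 3, comes from 1-hydroxy-1-methylethyl in place of trifluoromethyl on an aromatic carbon, with 1-hydroxy-1-methylethyl in place of trifluoromethyl on an aromatic carbon, ortho to a large group.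

Within the data shown here, only one measured step is available: a number 25 percentage points higher from compound 1 to compound 2 (beyond the scatter), a modest size, with chloro in place of hydrogen on an aromatic carbon. It exchanges different groups, so it bears on the present change only loosely, showing that a single exchange on the shared core can move this read-out beyond the scatter. Among the measured compounds shown here, no measured step replaces trifluoromethyl, and the data do not settle the direction. A modest fall is assumed here as a judgement, and the range is kept wide on both sides.

The expected step is a number 13 percentage points lower from compound 1 to compound 3 (beyond the scatter), which is modest and downward. For compound 3 the estimated value is 62%, with an expected range of 35% to 90%.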

Compound 3, percent of the compound remaining: 10%
For compound 3 the middle estimate is 52 percentage points above the measured one, outside the stated range (below it).
By their numbers in this assay, from the lowest: compound 3; then compound 1; then compound 2.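

In this assay, putting 1-hydroxy-1-methylethyl in place of trifluoromethyl gives a number 65 percentage points lower from compound 1 to compound 3 (beyond the scatter). Among these compounds, this shows that the aromatic carbon ortho to a large group is highly sensitive on this read-out: the exchange keeps the heavy-atom count and adds no ring or net charge, yet the step is large and downward, whereas the only earlier step, a number 25 percentage points higher from compound 1 to compound 2 (beyond the scatter), is modest and upward. The groups differ in the identity of their heavy atoms and in the hydrogen-bond donor and acceptor carried only by 1-hydroxy-1-methylethyl, but no accompanying measurement bears on the reason for the fall.

The compounds shown leave open whether the fall follows the hydroxyl or the branched carbon framework of the new group, a question on which an isopropyl group or a methoxy-bearing analogue of the same branched group could bear. They also leave open whether the chloro exchange that separates compound 1 from compound 2 would raise the number in the same way on a core carrying 1-hydroxy-1-methylethyl.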